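Swapping 4-hydroxycyclohexyl for 2-methoxyethyl: does stability hold?

The compounds below may be only part of what the source reports. "The series", "measured", "known", "first", "only" and "open" are said of these compounds alone.

Measured in an ADME assay on S9 fraction from liver (Rattus norvegicus) for metabolic stability, with a stated time of 60 min; on this read-out lower numbers stand for a less stable compound and higher numbers for a more stable compound:
- compound 1 `Cc1nc(-c2nc[nH]n2)ccc1-c1cnc2c(n1)N([C@H]1CC[C@@H](O)CC1)C(=O)CN2`: 100%
- compound 2 `Cc1nc(-c2nc[nH]n2)ccc1-c1cnc2c(n1)N([C@H]1CC[C@H](O)CC1)C(=O)CN2`: 91%

Compound 2 gives 91%, which lies within the usual scatter of compound 1: a number 9 percentage points lower from compound 1 to compound 2 (within the scatter). Compound 3 `COCCN1C(=O)CNc2ncc(-c3ccc(-c4nc[nH]n4)nc3C)nc21` keeps the shared core but carries a different group on the amide-type nitrogen in a ring: 2-methoxyethyl in place of 4-hydroxycyclohexyl on an amide-type nitrogen in a ring. Within the data shown here, the only measured step rests on (the fact that compounds 1 and 2 differ only in the configuration as drawn), so it compares two arrangements of the 4-hydroxycyclohexyl and never removes that group. It therefore gives no direct measure of this swap. Compound 2 at 91% leaves little room upward, so any change in this assay is expected to be downward rather than upward. The expected size is a number 6 percentage points lower from compound 2 to compound 3 (within the scatter), and this is uncertain. For compound 3 the estimated value is 85%, with an expected range from 62% to 100%.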

Compound 3, percent of the compound remaining: 91%
The estimate for compound 3 lay 6 percentage points below the measured number; measured number inside the range.
By their numbers in this assay, from the lowest: compounds 2, 3 and 1 (each within the scatter of the next).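

On the amide-type nitrogen in a ring, this assay shows that 2-methoxyethyl can stand in place of 4-hydroxycyclohexyl with the number staying within the scatter: the swap gives no change at the digits printed from compound 2 to compound 3 (within the scatter) and a number 9 percentage points lower from compound 1 to compound 3 (within the scatter). Compounds 1 and 2 only rearranged the 4-hydroxycyclohexyl group, whereas compound 3 has no six-membered carbon ring, no defined stereocentres and no hydrogen-bond donor in this group. For this read-out, then, none of those three features is needed at this position in this series.

Going by these compounds, whether a chain ending in an amine or a carboxylic acid would also hold the number at this position remains open. The compounds shown also offer no measured property that accounts for this result.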